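Swapping azido for dimethylamino on a shared core

The compounds below may be only part of what the source reports. "The series", "measured", "known", "first", "only" and "open" are said of these compounds alone.

Measured so far:
compound 1 `N#Cc1cc(=O)[nH]c(=O)n1[C@@H]1O[C@H](CO)[C@@H](O)[C@H]1O` — in a functional assay on OVCAR-4 cells (Homo sapiens) for antiproliferative activity, read by WST assay, with a stated time of 3 days (on this read-out lower numbers stand for stronger inhibition and higher numbers for weaker inhibition), compound 1 gives the limit > 50000 nM
compound 2 `[N-]=[N+]=Nc1cc(=O)[nH]c(=O)n1[C@@H]1O[C@H](CO)[C@@H](O)[C@H]1O` — compound 2 gives the limit > 50000 nM
compound 3 `COC(=O)c1cc(=O)[nH]c(=O)n1[C@@H]1O[C@H](CO)[C@@H](O)[C@H]1O` — compound 3 gives the limit > 50000 nM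

Each of these values is a limit of the assay rather than a number: the cells kept growing at every concentration tested. Compound 2 therefore stands where the other two stand, on the limit described by the limit of > 50000 nM in this assay, at which 3 of the 3 values shown sit. The three steps among them, a step that the two limits leave unreadable from compound 1 to compound 2, a step that the two limits leave unreadable from compound 1 to compound 3 and a step that the two limits leave unreadable from compound 2 to compound 3, are all unreadable, since a step between two limits has no measurable size.

Compound 4 `CN(C)c1cc(=O)[nH]c(=O)n1[C@@H]1O[C@H](CO)[C@@H](O)[C@H]1O` is the next candidate. Its change from compound 2 is dimethylamino in place of azido on an aromatic carbon. The only steps that bear on it are the three unreadable ones, so nothing shown suggests a readable step in this assay in either direction. Compound 4 is expected to give 60000 nM, within 15000 nM to 200000 nM, most likely again as a limit. The step from compound 2 to compound 4 that this estimate means is a step that the limit leaves unreadable from compound 2 to compound 4, expected to stay within scatter.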

Compound 4, half-maximal inhibitory concentration: > 50000 nM
Compound 4 was reported as a limit (the forecaster's own chance of this, stated with the estimate: 85%); the middle value lies beyond the limit too.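

Compound 4 gives > 50000 nM in this assay, and this is a limit of the assay. Its steps to compound 1, compound 2 and compound 3 therefore cannot be read, and all four compounds sit together: the limit of > 50000 nM in this assay, at which 4 of the 4 values shown sit.

The compounds shown leave open whether any group at this place on the shared core can give a measurable value in this assay.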